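Hepatocyte clearance notes: pyrazolyl in place of oxanyl

The compounds below may be only part of what the source reports. "The series", "measured", "known", "first", "only" and "open" are said of these compounds alone.

For the measured compounds named here, compound 2 `C[C@H](Nc1c(C(N)=O)nnc2ccc(-c3ccc(OCCCN4CCCC4)nc3)cc12)C1CCOCC1` holds the lowest of the two numbers so far in an ADME assay on cells (Hepatocyte, Rattus norvegicus) for metabolic stability, read by HPLC, with a stated time of 30 min, tested at 1 uM; on this read-out lower numbers stand for slow clearance and higher numbers for fast clearance: compound 2 gives 1.9 uL/min. The nearest neighbour, compound 1 `COCc1ccc(-c2ccc3nnc(C(N)=O)c(N[C@@H](C)c4ccn(C)n4)c3c2)cn1`, sits higher; in this assay compound 1 gives 4.9 uL/min, a gap that lies beyond the usual scatter. Compound 3 `C[C@H](Nc1c(C(N)=O)nnc2ccc(-c3ccc(OCCCN4CCCC4)nc3)cc12)c1ccn(C)n1` has not yet been measured. It differs from compound 2 in one place: 1-methyl-1H-pyrazol-3-yl in place of oxan-4-yl on a saturated chain carbon bound to a nitrogen on an aromatic ring and a saturated chain carbon Compound 1 carries the same entering group, 1-methyl-1H-pyrazol-3-yl, on the same kind of saturated chain carbon, though it is otherwise not the same molecule as compound 3. Going by the values given here, no step is on record for this exact change, so the expectation rests on compound 1 alone. A modest rise from compound 2 to compound 3, a 1.8-fold higher number from compound 2 to compound 3 (0.27 log units; within the scatter), is expected because compound 1 gives 4.9 uL/min, and the step may fall within the scatter. Compound 3 is estimated at 3.5 uL/min in this assay, with a range of 1.5 uL/min to 8 uL/min.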

Compound 3, intrinsic clearance in a liver preparation (reported as CLH), per the amount of preparation that the assay uses in the Hepatocyte assay: 4.6 uL/min
The estimate for compound 3 lay 1.3-fold (0.12 log units) below the measured number, within the range that was stated.
By their numbers in the Hepatocyte assay, from the lowest: compound 2; then compounds 3 and 1 (each within the scatter of the next).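

With 3-(pyrrolidin-1-yl)propoxy held fixed, 1-methyl-1H-pyrazol-3-yl in place of oxan-4-yl gives in the Hepatocyte assay a 2.4-fold higher number from compound 2 to compound 3 (0.38 log units; beyond the scatter) and so this change now has a size of its own on the saturated chain carbon. With 1-methyl-1H-pyrazol-3-yl held fixed, 3-(pyrrolidin-1-yl)propoxy in place of methoxymethyl on an aromatic carbon gives in the Hepatocyte assay a 1.1-fold lower number from compound 1 to compound 3 (0.03 log units; within the scatter) and so leaves that aromatic position without a readable effect in this pair. For the compounds shown here, in a physicochemical assay for lipophilicity, using the shake flask method, measured as octanol-water partition, with a stated time of 30 min, at pH 7.4 (a lower number here means a more polar compound, a higher number a more lipophilic compound), compound 2 gives 1.9 and compound 3 gives 1.8 with a number 0.10 log units lower from compound 2 to compound 3 (within the scatter) and so the clearance step has no matching step on this read-out.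

Still open, as far as these compounds go, is how an amine or a longer chain in place of 1-methyl-1H-pyrazol-3-yl on the saturated chain carbon would read in the Hepatocyte assay and whether the oxan-4-yl step holds with methoxymethyl on the aromatic carbon. Nothing at hand gives a reason for the clearance step.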